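The source may report more compounds than this note shows. Statements on the series, on what has been measured and on what is new or still open speak of the compounds shown alone.

The measured compounds are compound 1, `CCCCCCCCC(=O)N1c2ccccc2CCC1C(=O)Nc1ccccc1C(F)(F)F`, compound 2, `O=C(Nc1ccccc1C(F)(F)F)C1CCc2ccccc2N1C(=O)c1ccccc1`, and compound 3, `CCCCCCCCC(=O)N1c2ccccc2CCC1C(=O)Nc1ccccc1O`. In a functional assay on PC-3 cells (Homo sapiens) for cytotoxicity, read by sulforhodamine B assay, with a stated time of 72 h (on this read-out lower numbers stand for stronger inhibition of growth and higher numbers for weaker inhibition of growth), compound 1 gives 4320 nM, compound 2 gives 5560 nM, and compound 3 gives 45200 nM.

Compound 2 differs from compound 1 by phenyl in place of octyl on a carbonyl carbon; this change made a 1.3-fold higher number from compound 1 to compound 2 (0.11 log units; within the scatter). Compound 3 differs from compound 1 by hydroxy in place of trifluoromethyl on an aromatic carbon; this change made a 10-fold higher number from compound 1 to compound 3 (1.02 log units; beyond the scatter), and compound 3 gives the highest number of the three.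

Compound 4, `O=C(Nc1ccccc1O)C1CCc2ccccc2N1C(=O)c1ccccc1`, has not yet been measured in this assay. It differs from compound 3 by phenyl in place of octyl on a carbonyl carbon, the same change as from compound 1 to compound 2, at the same place, a carbonyl carbon whose other neighbours are an amide-type nitrogen in a ring. The two cores differ as described for compound 3 against compound 1, so the change occurs twice among these compounds, here on the hydroxy-bearing core.

Because the earlier occurrence made a 1.3-fold higher number from compound 1 to compound 2 (0.11 log units; within the scatter), the expected step is a 1.2-fold higher number from compound 3 to compound 4 (0.09 log units; within the scatter). Compound 4 is accordingly estimated at 55000 nM in this assay, most likely between 25000 nM and 120000 nM.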

Compound 4, concentration for 50% growth inhibition: 5690 nM
Compound 4: the middle estimate sits 9.7-fold (0.99 log units) above what was measured; measured number below the stated range.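

In this assay, phenyl in place of octyl on a carbonyl carbon did not carry over from the core of compound 1 to the hydroxy-bearing core, where it made a 7.9-fold lower number from compound 3 to compound 4 (0.90 log units; beyond the scatter), and the two occurrences disagree: the same change on two cores in this assay, a 1.3-fold higher number (0.11 log units; within the scatter) from compound 1 to compound 2 and a 7.9-fold lower number (0.90 log units; beyond the scatter) from compound 3 to compound 4, 10-fold (1.01 log units) apart, beyond the scatter of two such steps. The exchange of trifluoromethyl for hydroxy on an aromatic carbon likewise depends on its partner, since with the benzoyl group it made a 1.0-fold higher number from compound 2 to compound 4 (0.01 log units; within the scatter), and this too disagrees with its earlier occurrence: the same change on two cores in this assay, a 10-fold higher number (1.02 log units; beyond the scatter) from compound 1 to compound 3 and a 1.0-fold higher number (0.01 log units; within the scatter) from compound 2 to compound 4, 10-fold (1.01 log units) apart, beyond the scatter of two such steps. These two gaps show that, among these compounds, a step read on one core cannot simply be transferred to another, but they come from the same four compounds, so they amount to one observation and do not show why the steps differ or how general this is.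

The compounds shown leave open whether a shorter chain such as butyl on the carbonyl would follow octyl or phenyl on the hydroxy-bearing core. They also leave open whether an amine or a carboxylic acid in place of hydroxy would behave as hydroxy does.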